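Piperidine for methylpiperazine on two related cores

This account rests on a few compounds, and the source may have more. Where it says the series, first, only, none or still open, it means among the compounds named here.

Compound 1 `CN1CCN(c2ccc(Nc3ncc4c(n3)N(C3CCCC3)CC(=O)N4C)nc2)CC1` gives 11100 nM in a functional assay on HT-29 cells (Homo sapiens) for inhibition, read by MTT assay, with a stated time of 48 h; on this read-out higher numbers stand for weaker inhibition and lower numbers for stronger inhibition. Compound 2 `CN1C(=O)CN(C2CCCC2)c2nc(Nc3ccc(N4CCCCC4)cn3)ncc21` gives 12500 nM in this assay. Compound 3 `CCN1C(=O)CN(C2CCCC2)c2nc(Nc3ccc(N4CCN(C)CC4)cc3)ncc21` gives 10300 nM in this assay.

In this assay the three measured compounds sit close together, and no one of them can be called the strongest or weakest. From compound 1 to compound 2 the change is piperidin-1-yl in place of 4-methylpiperazin-1-yl on an aromatic carbon, and it produced a 1.1-fold higher number from compound 1 to compound 2 (0.05 log units; within the scatter). Compound 4 `CCN1C(=O)CN(C2CCCC2)c2nc(Nc3ccc(N4CCCCC4)cc3)ncc21` has not yet been measured; it differs from compound 3 by piperidin-1-yl in place of 4-methylpiperazin-1-yl on an aromatic carbon. For the measured compounds named here, this is the same kind of change as the one from compound 1 to compound 2, but not the same: there the group sits on a six-membered aromatic ring with 1 nitrogen, two atoms from the ring nitrogen, para to a large group, whereas here it sits on a six-membered aromatic ring of carbon only, para to a large group. The difference between the core of compound 1 and the core of compound 3 is not broken down here. Because a 1.1-fold higher number from compound 1 to compound 2 (0.05 log units; within the scatter) stayed within the scatter, compound 4 is expected to show a 1.1-fold higher number from compound 3 to compound 4 (0.05 log units; within the scatter) in this assay, a step of about the same size as the earlier one. Compound 4 is therefore estimated at 11500 nM in this assay, with a range of 5000 nM to 30000 nM.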

Compound 4, half-maximal inhibitory concentration: > 30000 nM
Compound 4: only a limit was reported (the forecaster's own chance of this, stated with the estimate: 15%); at least 2.6-fold (0.41 log units) between middle value and limit.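

Putting piperidin-1-yl in place of 4-methylpiperazin-1-yl gave an at least 2.9-fold higher number from compound 3 to compound 4 (0.46 log units; beyond the scatter) in this assay, a step beyond the scatter, while the same kind of change on the other core gave a 1.1-fold higher number from compound 1 to compound 2 (0.05 log units; within the scatter). Compound 4 is reported only as a limit, > 30000 nM. The step that stayed within the scatter on one core is thus not simply repeated in size on the other, but this does not show how far the two steps lie apart, or even that they truly differ: the same change on two cores in this assay, a 1.1-fold higher number (0.05 log units; within the scatter) from compound 1 to compound 2 and an at least 2.9-fold higher number (0.46 log units; beyond the scatter) from compound 3 to compound 4; the limit leaves it open whether they differ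

The compounds shown leave open how other groups in the same place, such as morpholine or an unsubstituted piperazine, would behave on either core. They also do not separate the ring that carries the group, with 1 nitrogen on one core and of carbon only on the other, from the remaining differences between the two cores.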